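Nitrophenyl in place of fluorobenzyl: cytotoxicity outlook

This account rests on a few compounds, and the source may have more. Where it says the series, first, only, none or still open, it means among the compounds named here.

Cytotoxicity is followed in an ADME assay on Huh-7 cells (Homo sapiens) for cytotoxicity (on this read-out higher numbers stand for lower toxicity in this test and lower numbers for higher toxicity in this test), across a small set sharing one core. Compound 1 `Cc1ccccc1-c1nn(Cc2ccc(F)cc2)cc1CNCCN1CCN(C)CC1` gives > 20000 nM in this assay, and this value is a limit rather than a number. Compound 2 `CCCN1CCC(CNCc2cn(-c3ccc(F)cc3F)nc2-c2ccccc2C)CC1` likewise returns only a limit, > 20000 nM. Going by the values given here, compound 3 `CN1CCN(CCNCc2cn(-c3ccc(F)cc3F)nc2-c2ccc(Cl)cc2)CC1` is the sole member with a measured number, giving 19000 nM in this assay. Compound 1 therefore stands at the limit of > 20000 nM in this assay, at which 2 of the 3 values shown sit, and no finer placement within the set is possible. Among the compounds with values here, no pair of measured compounds differs in a single place, so no step size has been measured here.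

Compound 4 `Cc1ccccc1-c1nn(-c2ccc([N+](=O)[O-])cc2)cc1CNCCN1CCN(C)CC1` differs from compound 1 by 4-nitrophenyl in place of 4-fluorobenzyl on an aromatic nitrogen. Given that the surrounding values sit at or close to the limit, the step of a number no higher from compound 1 to compound 4 (the limit leaves the size open) is expected to be none beyond the scatter. For compound 4 the estimate in this assay is 20000 nM, with a range from 8000 nM to 40000 nM, and a report of only a limit remains likely.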

Compound 4, half-maximal cytotoxic concentration: > 20000 nM
Compound 4 was reported as a limit (the forecaster's own chance of this, stated with the estimate: 55%); the middle value sits exactly at the limit.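

Compound 1 and compound 4 both return only a limit in this assay, so no step between them can be read: the limit of > 20000 nM in this assay, at which 3 of the 4 values shown sit.

Still open, on these data alone, is whether 4-nitrophenyl in place of 4-fluorobenzyl on an aromatic nitrogen shifts the half-maximal cytotoxic concentration at all.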